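A few compounds are considered here, and "the series" means these few. Any claim that something is new, unique, unknown or untested is made for them only; others in the source may bear on it.

Of the compounds shown here, three have been measured in a functional assay on cells for positive allosteric modulation of metabotropic glutamate receptor 2 (Homo sapiens), read by fluorescence and calcium flux, with a stated time of 30 min; on this read-out lower numbers stand for an effect already at smaller amounts and higher numbers for an effect only at larger amounts of compound. Compound 1 `c1ccc(-c2ccc(Cn3nnc4ccccc43)cc2)cc1` gives 155 nM, compound 2 `Brc1cccc2c1nnn2CC1CC1` gives 70 nM, and compound 3 `FC(F)(F)c1cc(Br)c2nnn(CC3CC3)c2c1` gives 140 nM. Compound 3 thus differs from both compound 1 and compound 2 by less than the usual scatter of this assay. For the measured compounds named here, the one single-point step seen so far, a 2.0-fold higher number from compound 2 to compound 3 (0.30 log units; within the scatter), is trifluoromethyl in place of hydrogen on an aromatic carbon. Compound 4 `Brc1cc(Br)c2nnn(CC3CC3)c2c1` carries the change (bromo in place of trifluoromethyl on an aromatic carbon). Going by the values given here, no measured step covers this exchange, and the only related step, from compound 2 to compound 3, stayed within the scatter, so no change beyond the scatter is expected, a 1.3-fold lower number from compound 3 to compound 4 (0.10 log units; within the scatter). Compound 4 is therefore estimated at 110 nM, between 40 nM and 300 nM.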

Compound 4, half-maximal effective concentration: 50 nM
Beside the measured number, compound 4's estimate is 2.2-fold (0.34 log units) above it; measured number inside the range.
By their numbers in this assay, from the lowest: compounds 4, 2, 3 and 1 (each within the scatter of the next, the first and the last beyond it).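

For the compounds shown here, the exchange of groups at this position gives a 2.8-fold lower number from compound 3 to compound 4 (0.45 log units; beyond the scatter) and is the first step to clear the scatter, though only modestly. Measured against hydrogen at the same position, neither group clears it, with a 2.0-fold higher number from compound 2 to compound 3 (0.30 log units; within the scatter) and a 1.4-fold lower number from compound 2 to compound 4 (0.15 log units; within the scatter) as the two steps, so only the difference between bromo and trifluoromethyl can be read here. Nothing at hand offers an explanation for that difference.
Still open, going by these compounds, is how chloro, methoxy, an amine or a carboxylic acid would fare on this aromatic carbon. On these data alone, whether the difference between bromo and trifluoromethyl would hold on a different core also stays unknown.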